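Changing one aromatic group on compound 2

This account rests on a few compounds, and the source may have more. Where it says the series, first, only, none or still open, it means among the compounds named here.

Within the data shown here, in a functional assay on MDA-MB-231 cells (Homo sapiens) for cytotoxicity, read by MTT assay, with a stated time of 48 h (a higher number here means a weaker inhibitor, a lower number a stronger inhibitor), compound 2 `O=C(NCCCCC(c1ccc(F)cc1)c1ccc(F)cc1)Nc1ccc(C(F)(F)F)cc1` gives 2780 nM and holds the lower of the two numbers measured so far. Among the measured compounds shown here, its only comparison is compound 1 `O=C(NCCCCC(c1ccc(F)cc1)c1ccc(F)cc1)Nc1ccc(Cl)cc1` with 7680 nM in this assay on the same scale. For the measured compounds named here, the single measured step is a 2.8-fold lower number from compound 1 to compound 2 (0.44 log units; beyond the scatter) and it comes with trifluoromethyl in place of chloro on an aromatic carbon.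

The next molecule, compound 3 `Cc1cccc(NC(=O)NCCCCC(c2ccc(F)cc2)c2ccc(F)cc2)c1` differs from compound 2 as follows: 3-methylphenyl in place of 4-(trifluoromethyl)phenyl on an amide-type nitrogen with 3-methylphenyl in place of 4-(trifluoromethyl)phenyl on an amide-type nitrogen. Going by the values given here, no measured compound yet carries the 3-methylphenyl group, so the evidence is thin. The step of a 2.8-fold lower number from compound 1 to compound 2 (0.44 log units; beyond the scatter) bears on this change only in part, though it does show a modest shift when the trifluoromethyl group is exchanged on the aromatic group. A move of similar modest size toward a higher number in this assay is therefore expected, with a wide margin of doubt.

The step expected is a 2.2-fold higher number from compound 2 to compound 3 (0.33 log units; beyond the scatter) in this assay for now. The estimated value for compound 3 is 6000 nM with an expected range from 2500 nM to 15000 nM until a measurement settles it.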

Compound 3, half-maximal inhibitory concentration: > 20000 nM
Compound 3: only a limit was reported (the forecaster's own chance of this, stated with the estimate: 5%); middle value at least 3.3-fold (0.52 log units) away from the limit.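

In this assay compound 3 gives > 20000 nM, which is a limit and not a number, so the size of its steps is known from one side only: the limit of > 20000 nM in this assay, at which 1 of the 3 values shown sits.

Even so, the aromatic group on the amide-type nitrogen proves able to shift the result further than the earlier compounds showed, since the modest 2.8-fold lower number from compound 1 to compound 2 (0.44 log units; beyond the scatter) is now joined by an at least 7.1-fold higher number from compound 2 to compound 3 (0.85 log units; beyond the scatter). The exchange of 4-chlorophenyl for 3-methylphenyl points the same way, with an at least 2.6-fold higher number from compound 1 to compound 3 (0.41 log units; beyond the scatter), which makes compound 3 the weakest of the three compounds shown, with both of its steps beyond the scatter.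

The change from 4-(trifluoromethyl)phenyl to 3-methylphenyl alters both the group on the ring and its place there in a single step, and the compounds shown do not separate these two changes. Also open, from the compounds shown here alone, is how an aromatic group carrying a nitrile or an amine, or a longer chain between the urea and the two 4-fluorophenyl groups, would read in this assay.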